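Trimming the amide side chain of compound 2

The compounds below may be only part of what the source reports. "The series", "measured", "known", "first", "only" and "open" are said of these compounds alone.

Measured so far in a physicochemical assay for lipophilicity, at pH 7.4; on this read-out higher numbers stand for higher lipophilicity and lower numbers for lower lipophilicity:
- compound 1 (`CNc1ccnc2c(O)c(-c3nc(C)n[nH]3)ncc12`) (-0.2)
- compound 2 (`O=C(NCc1ccc(Cl)cc1)c1ncc2ccccc2c1O`) (7.6)

Compound 2 (7.6) holds the higher of the two numbers, and compound 1 (-0.2) lies lower by a margin well beyond the scatter. Among the measured compounds shown here, these two compounds are not related by a change in one place, so the series offers no measured step to use as a yardstick.

Compound 3 (`O=C(NCC1CC1)c1ncc2ccccc2c1O`) is next in line for measurement. It carries cyclopropyl in place of 4-chlorophenyl on a saturated chain carbon bound to an amide-type nitrogen. The group that enters is the smaller one, and compound 2 starts from a high number (7.6), so a fall is the likelier direction. For the measured compounds named here, the expected change (a number 1.80 log units lower from compound 2 to compound 3 (beyond the scatter)) is a downward step beyond the scatter in this assay, although this estimate has no measured step behind it and its range is kept wide.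

For compound 3 the estimated value is 5.8 with an expected range from 4.4 to 6.9 on this read-out.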

Compound 3, distribution coefficient: 3.3
The estimate for compound 3 lay 2.50 log units above the measured number; measured number outside the range, below it.
By their numbers in this assay, from the lowest: compound 1; then compound 3; then compound 2.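

In this assay, cyclopropyl in place of 4-chlorophenyl on a saturated chain carbon bound to an amide-type nitrogen gives the series its first measured step, a number 4.30 log units lower from compound 2 to compound 3 (beyond the scatter), and that step is large. This position is therefore far from silent on this read-out: a single exchange, with 7 heavy atoms leaving, 3 entering and no hydrogen-bond donors or acceptors on either side, accounts for the whole step. No measurement at hand bears on the cause of this step.

The exchange removes the chlorine, the six-membered aromatic ring and part of the heavy-atom count all at once, so this one step cannot divide its size among those changes. As far as these compounds go, whether plain phenyl, which keeps the aromatic ring and loses only the chlorine, or cyclohexyl, which keeps a saturated carbon ring of the same size as that aromatic ring, would stand nearer compound 2 or nearer compound 3 remains open, as does the effect of an amine at this position.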